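Swapping a Urea for a Benzylamide: Expected Cytotoxicity

This account rests on a few compounds, and the source may have more. Where it says the series, first, only, none or still open, it means among the compounds named here.

Of the compounds shown here, three have so far been tested in an ADME assay on MT4 cells (Homo sapiens) for cytotoxicity, read by MTT assay; on this read-out higher numbers stand for lower toxicity in this test and lower numbers for higher toxicity in this test. Compound 1 `Cc1ccc(-c2c(C)nc(NC(=O)NC3CCCCC3)c(C)c2C(OC(C)(C)C)C(=O)O)cc1C` gives 7900 nM, compound 2 `Cc1ccc(-c2c(C)nc(NS(=O)(=O)c3cccc4ccccc34)c(C)c2C(OC(C)(C)C)C(=O)O)cc1C` gives 16000 nM, and compound 3 `Cc1ccc(-c2c(C)nc(NC(=O)Nc3ccccc3)c(C)c2C(OC(C)(C)C)C(=O)O)cc1C` gives 9900 nM, the second highest of the three numbers; its gap to compound 1 and its gap to compound 2 both lie within the scatter. Within the data shown here, the only single-point step measured, a 1.3-fold higher number from compound 1 to compound 3 (0.10 log units; within the scatter), is within the scatter. Compound 4 `Cc1ccc(-c2c(C)nc(C(=O)NCc3ccccc3)c(C)c2C(OC(C)(C)C)C(=O)O)cc1C` differs from compound 3 in one place: benzylcarbamoyl in place of (phenylcarbamoyl)amino on an aromatic carbon. Among the measured compounds shown here, no measured step covers this particular change, and the one step that touches the same position was flat, so for compound 4 no step beyond the scatter is expected in this assay, no change at the digits printed from compound 3 to compound 4 (within the scatter). Compound 4 is therefore estimated at 9900 nM, within 4000 nM to 25000 nM.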

Compound 4, half-maximal cytotoxic concentration: 54000 nM
Estimate against measurement, compound 4: 5.5-fold (0.74 log units) below; the whole stated range lies below it.
By their numbers in this assay, from the lowest: compounds 1, 3 and 2 (each within the scatter of the next, the first and the last beyond it); then compound 4.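

Replacing the urea linkage itself moves the number in this assay, where swapping its end ring did not: benzylcarbamoyl gives a 5.5-fold higher number from compound 3 to compound 4 (0.74 log units; beyond the scatter) and a 6.8-fold higher number from compound 1 to compound 4 (0.83 log units; beyond the scatter) in this test. At this aromatic carbon next to the ring nitrogen, then, the linkage matters more to the read-out than the phenyl or cyclohexyl end group, and the amide goes with lower toxicity in this test. Nothing available explains this step. As far as these compounds go, whether the step belongs to the reversed amide or to the methylene before the phenyl ring stays open. A phenylcarbamoyl or 2-phenylethylcarbamoyl group at this place would separate the two.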